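Ester chain length and cytotoxicity: outlook for compound 4

This account rests on a few compounds, and the source may have more. Where it says the series, first, only, none or still open, it means among the compounds named here.

Working notes on the series. The shared core of compound 1 `CCCCCCOC(=O)CCC(=O)N1CCN(CCCOc2cc3c(Nc4ccc(F)c(Cl)c4)ncnc3cc2OC)CC1` carries an ester whose alcohol chain is lengthened step by step across the set. In a functional assay on A549 cells (Homo sapiens) for cytotoxicity, read by MTT assay, with a stated time of 24 h, tested at 60 uM (a lower number here means a stronger effect, a higher number a weaker effect of the compound at the concentration tested), compound 1 gives 63.6%. Compound 2 `CCCCCCCCCCOC(=O)CCC(=O)N1CCN(CCCOc2cc3c(Nc4ccc(F)c(Cl)c4)ncnc3cc2OC)CC1` gives 3.9%, and compound 3 `CCCCCCCCCCCCCOC(=O)CCC(=O)N1CCN(CCCOc2cc3c(Nc4ccc(F)c(Cl)c4)ncnc3cc2OC)CC1` gives 20.6%. The step of a number 59.7 percentage points lower from compound 1 to compound 2 (beyond the scatter) is large, as is a number 43 percentage points lower from compound 1 to compound 3 (beyond the scatter); the step of a number 16.7 percentage points higher from compound 2 to compound 3 (beyond the scatter) runs the other way and is modest. Compound 3 therefore stands second highest of the three numbers, nearer to compound 2 than to compound 1.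

Compound 4 `CCCCCCCCCCCCCCOC(=O)CCC(=O)N1CCN(CCCOc2cc3c(Nc4ccc(F)c(Cl)c4)ncnc3cc2OC)CC1` differs from compound 3 by methyl in place of hydrogen on a saturated chain carbon, ten or more bonds along the chain from an oxygen next to a carbonyl group. The step that bears most directly on this change is a number 16.7 percentage points higher from compound 2 to compound 3 (beyond the scatter), which added propyl at the same kind of place and raised the number modestly; the larger additions in a number 59.7 percentage points lower from compound 1 to compound 2 (beyond the scatter) and a number 43 percentage points lower from compound 1 to compound 3 (beyond the scatter) lowered it. One methyl is a smaller addition than any measured step, so in this assay a step of a number 5.4 percentage points higher from compound 3 to compound 4 (within the scatter) is expected, upward if anything and possibly within the scatter. Compound 4 is accordingly estimated at 26%, with a range of 8% to 46%.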

Compound 4, a percentage reported as activity, at one concentration (the size of the read-out at that concentration, not a potency): 84.9%
Compound 4: the middle estimate sits 58.9 percentage points below what was measured; the whole stated range lies below it.
By their numbers in this assay, from the lowest: compound 2; then compound 3; then compound 1; then compound 4.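

In this assay, a single methyl on a saturated chain carbon gives a number 64.3 percentage points higher from compound 3 to compound 4 (beyond the scatter), so the smallest addition in the series produces a large step, and the size of a step does not follow the size of the addition. The longest chain also gives a number 81 percentage points higher from compound 2 to compound 4 (beyond the scatter) and even a number 21.3 percentage points higher from compound 1 to compound 4 (beyond the scatter), so the number falls and then rises along these four compounds, with its lowest point at compound 2 and its highest at compound 4. Nothing available here bears on this sharp reversal.

On these data alone, whether the number stays high with a still longer chain remains open. So does whether a chain ending in an amine or a carboxylic acid at this place would behave in the same way.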